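The compounds below may be only part of what the source reports. "The series", "measured", "known", "first", "only" and "open" are said of these compounds alone.

Compound 1 `COc1ccc(/C=N\NC(=S)NC(C)(C)CCC[C@](C)(O)[C@@H]2CC=C(C)CC2)cc1` gives 220 nM in a functional assay on K562 cells (Homo sapiens) for cytotoxicity, read by sulforhodamine B assay; a lower number here means a stronger inhibitor of growth, a higher number a weaker inhibitor of growth. Among the compounds with values here, compound 2 `CC1=CC[C@@H]([C@@](C)(O)CCCC(C)(C)NC(=S)N/N=C\c2ccccc2Cl)CC1`, in which a 2-chlorophenyl stands in place of the 4-methoxyphenyl on the carbon with a double bond to nitrogen, gives 150 nM in this assay; the step of a 1.5-fold lower number from compound 1 to compound 2 (0.17 log units; within the scatter) is the only measured step, and it lies within the scatter. Compound 2 thus shows the lower of the two numbers, but nothing beyond the scatter separates it from compound 1.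

Compound 3 `CC1=CC[C@@H]([C@@](C)(O)CCCC(C)(C)NC(=S)N/N=C(/C)c2ccccc2)CC1` differs from compound 2 by a group of 9 heavy atoms (8 carbon, 1 nitrogen; one six-membered aromatic ring of carbon only) in place of a group of 9 heavy atoms (7 carbon, 1 nitrogen, 1 chlorine; one six-membered aromatic ring of carbon only), on an amide-type nitrogen. Within the data shown here, the one measured step, from compound 1 to compound 2, also exchanged the aryl part of this group without moving the number beyond the scatter, so the step of a 1.3-fold higher number from compound 2 to compound 3 (0.12 log units; within the scatter) in this assay is expected to stay small as well, with no clear direction. Compound 3 is therefore estimated at 200 nM in this assay, in a range from 80 nM to 500 nM.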

Compound 3, concentration for 50% growth inhibition: 10 nM
Compound 3: middle estimate off by 20-fold (1.30 log units), on the high side; measured number below the stated range.
By their numbers in this assay, from the lowest: compound 3; then compounds 2 and 1 (each within the scatter of the next).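

The group on the amide-type nitrogen proves sensitive in this assay, since exchanging it gives a 15-fold lower number from compound 2 to compound 3 (1.18 log units; beyond the scatter) and a 22-fold lower number from compound 1 to compound 3 (1.34 log units; beyond the scatter), whereas the earlier exchange on this group stayed within the scatter. Both large steps end at the same group of 8 carbon and 1 nitrogen, which carries neither the chlorine nor the oxygen of the groups it replaces, and the two groups it replaces cannot be told apart by their numbers. No supporting measurement is available to explain this change.

The compounds shown leave open which part of the exchange carries the step, as the groups differ in more than one atom. They also leave open how an amine or a carboxylic acid on the six-membered aromatic ring of this group would read in this assay.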